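The source may hold more compounds than are shown below. What is called first, only, known or untested is meant among the compounds shown, and "the series" means these compounds.

Measured so far:
compound 1, `Cc1cccc(NC(=O)N[C@@H]2C[C@H](c3ccccc3C)C[C@H](c3ccccc3)N(CC(=O)NC(C)(C)C)C2=O)c1`, 610 nM; 580 nM; 930 nM (3 entries);
compound 2, `Cc1cccc(NC(=O)N[C@@H]2C[C@H](c3ccccc3C)C[C@H](c3ccccc3)N(CC(=O)NC3(C)CCCCC3)C2=O)c1`, 4.4 nM.

In an assay on isolated protein for inhibition of Cholecystokinin receptor type A (Cavia porcellus) (on this read-out higher numbers stand for weaker inhibition and lower numbers for stronger inhibition), compound 1 gives 610 nM; 580 nM; 930 nM (3 entries), with repeated entries recorded as the several entries of compound 1 in this assay, 610 nM; 580 nM; 930 nM (3 entries). In this assay compound 2 gives 4.4 nM; that is the only number shown for it, and one further entry carries no single number. Compound 3, `Cc1cccc(NC(=O)N[C@@H]2C[C@H](c3ccccc3C)C[C@H](c3ccccc3)N(CC(=O)NC(C(C)(C)C)C(C)(C)C)C2=O)c1`, is not yet measured; it differs from compound 2 by 2,2-dimethyl-1-(tert-butyl)propyl in place of 1-methylcyclohexyl on an amide-type nitrogen. Among the measured compounds shown here, with no measured step of this kind to lean on, a moderate shift towards weaker inhibition is expected, a 4.5-fold higher number from compound 2 to compound 3 (0.66 log units; beyond the scatter). Compound 3 is therefore estimated at 20 nM, in the range 4 nM to 150 nM.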

Compound 3, half-maximal inhibitory concentration: > 10 nM
Compound 3 ended at the assay's limit; the forecaster's own chance of this, stated with the estimate: 3%; the middle value lies beyond the limit too.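

In this assay, putting 2,2-dimethyl-1-(tert-butyl)propyl in place of 1-methylcyclohexyl on the amide-type nitrogen gives an at least 2.2-fold higher number from compound 2 to compound 3 (0.35 log units; beyond the scatter). This shows that the ring-free group with more carbon atoms does not retain the value of compound 2. For compound 3, > 10 nM is a limit of the assay and not a number, so the step gives only a lower bound on the change. As far as these compounds go, the actual value of compound 3 remains open, as does what an amine or a carboxylic acid at this amide-type nitrogen would give in this assay.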